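A few compounds are considered here, and "the series" means these few. Any claim that something is new, unique, unknown or untested is made for them only; others in the source may bear on it.

Measured in a functional assay on A549 cells (Homo sapiens) for cytotoxicity, read by MTT assay, with a stated time of 48 h; on this read-out higher numbers stand for weaker inhibition and lower numbers for stronger inhibition:
- compound 1 `COc1c(OCc2cnoc2C)cc(O)c2c(=O)cc(-c3ccccc3)oc12`: > 100000 nM (a limit)
- compound 2 `COc1c(OCCCCN2CCNCC2)cc(O)c2c(=O)cc(-c3ccccc3)oc12`: 1740 nM
- compound 3 `CCCCNCCCCOc1c(O)cc(O)c2c(=O)cc(-c3ccccc3)oc12`: "not determined" (no result reported)

Among these entries, compound 2 at 1740 nM holds the only actual number in this assay. Compound 1 reaches only a limit of the assay, > 100000 nM. Compound 3 gives no result, so it offers no comparison.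

Next is compound 4 `COc1c(OCCCCNCc2ccccc2)cc(O)c2c(=O)cc(-c3ccccc3)oc12`, with the change benzylamino in place of piperazin-1-yl on a saturated chain carbon, four bonds along the chain from an oxygen on an aromatic ring.

Within the data shown here, the one measured step is an at least 57-fold lower number from compound 1 to compound 2 (1.75 log units; beyond the scatter), large and beyond the scatter, with its starting point set by the limit of > 100000 nM in this assay, at which 1 of the 3 values shown sits. That step replaced the whole 5-methyl-1,2-oxazol-4-yl end with 3-(piperazin-1-yl)propyl, whereas compound 4 differs only in the group at the chain end. A step of that size is therefore not expected here. The expected change is a 2.3-fold higher number from compound 2 to compound 4 (0.36 log units; beyond the scatter), a moderate move towards weaker inhibition. For compound 4 the estimate is 4000 nM, with an expected range of 1000 nM to 25000 nM.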

Compound 4, half-maximal inhibitory concentration: 4590 nM
For compound 4 the middle estimate is 1.1-fold (0.06 log units) below the measured one; low and high end bracket the measured number.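

In this assay, benzylamino in place of piperazin-1-yl on a saturated chain carbon, four bonds along the chain from an oxygen on an aromatic ring, gives a 2.6-fold higher number from compound 2 to compound 4 (0.42 log units; beyond the scatter), so this chain end accepts an open benzylamino group with one nitrogen and an aromatic ring at a modest cost. The second amine end also keeps the large separation from the 5-methyl-1,2-oxazol-4-yl end, with an at least 21-fold lower number from compound 1 to compound 4 (1.33 log units; beyond the scatter). Compound 1 stands at a limit, so that step gives a bound and not a measured size: the limit of > 100000 nM in this assay, at which 1 of the 4 values shown sits.

Still open, on these data alone, is whether the separation from compound 1 follows the amine nitrogen, the chain or both. A morpholin-4-yl or dimethylamino end, or a longer chain carrying the benzylamino group, would bear on this.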